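Benzylamino for aryloxy on a quinoxaline-type core: compound 4

The source may report more compounds than this note shows. Statements on the series, on what has been measured and on what is new or still open speak of the compounds shown alone.

Measured compounds:
- compound 1 `Nc1cc(N)c2nc(-c3ccccc3)c(Oc3ccc(Cl)c(Cl)c3)nc2c1`: 24000 nM
- compound 2 `COc1cc(CNc2nc3cc(N)cc(N)c3nc2-c2ccccc2)cc(OC)c1OC`: 5370 nM
- compound 3 `CCOC(=O)[C@H](CCC(=O)O)NC(=O)c1ccc(CNc2nc3cc(N)cc(N)c3nc2-c2ccccc2)cc1`: < 100000 nM

In a functional assay on SK-OV-3 cells (Homo sapiens) for inhibition, read by sulforhodamine B assay, with a stated time of 48 h (on this read-out lower numbers stand for stronger inhibition of growth and higher numbers for weaker inhibition of growth), compound 1 gives 24000 nM, the highest of the two plain numbers in the set. Compound 2, which carries a substituted benzylamino group in the same position, gives 5370 nM in this assay, a value that sits beyond the scatter below that of compound 1. Compound 3 is reported only as a limit of the assay, < 100000 nM, and is therefore one of the values in this assay that sit at the limit of < 100000 nM in this assay, at which 1 of the 3 values shown sits.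

Compound 4 `Nc1cc(N)c2nc(-c3ccccc3)c(NCc3ccc(F)cc3)nc2c1` has not yet been tested. It differs from compound 1 in one place: (4-fluorobenzyl)amino in place of 3,4-dichlorophenoxy on an aromatic carbon. Going by the values given here, no step between measured compounds matches this change, but compound 1 gives 24000 nM whereas compound 2, which carries a benzylamino group at this position, gives 5370 nM, a lower number. The step from compound 1 to compound 4 is therefore expected to be a 2.7-fold lower number from compound 1 to compound 4 (0.43 log units; beyond the scatter), toward stronger inhibition, though not far beyond the scatter. Compound 4 is estimated at 9000 nM, with a likely range from 2500 nM to 30000 nM.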

Compound 4, concentration for 50% growth inhibition: 12900 nM
The estimate for compound 4 lay 1.4-fold (0.16 log units) below the measured number; the measured number falls inside the stated range.
By their numbers in this assay, from the lowest: compound 2; then compounds 4 and 1 (each within the scatter of the next).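

In this assay, putting (4-fluorobenzyl)amino in place of 3,4-dichlorophenoxy on this aromatic carbon, next to the ring nitrogen, gives a 1.9-fold lower number from compound 1 to compound 4 (0.27 log units; within the scatter), so the two groups cannot be told apart at this position by this read-out. Going by these compounds alone, this is the first comparison at this position in which only that group changes, and the entering group carries a hydrogen-bond donor that the leaving group lacks, without a step beyond the scatter. Nothing measured here gives a reason for the size of this step.

Going by these compounds, a 3,4-dichlorobenzylamino group would keep the ring substituents of compound 1 and change only the link, so the role of the link itself stays open. Also open, on these data alone, is how an unsubstituted benzylamino group or a longer phenethylamino chain would behave here.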